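The source may report more compounds than this note shows. Statements on the series, on what has been measured and on what is new or still open speak of the compounds shown alone.

In a functional assay on BXPC-3 cells (Homo sapiens) for antiproliferative activity, read by MTT assay, with a stated time of 24 h (on this read-out higher numbers stand for weaker inhibition and lower numbers for stronger inhibition), compound 3 `CCn1c(C(=O)NCCCO)ccc1C(CC)(CC)c1ccc(OCS(=O)(=O)c2ccccc2)c(C)c1` gives 26600 nM. Compound 1 `CCn1c(C(=O)N[C@@H](C)C(=O)OC)ccc1C(CC)(CC)c1ccc(OCS(=O)(=O)c2ccccc2)c(C)c1` gives 17900 nM, and the step between them is a 1.5-fold higher number from compound 1 to compound 3 (0.17 log units; within the scatter), so these two cannot be told apart. Compound 2 `CCn1c(C(=O)NCCC(=O)OC)ccc1C(CC)(CC)c1ccc(OCS(=O)(=O)c2ccccc2)c(C)c1` reads > 50000 nM, which is a limit and not a number.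

The change now in view leads to compound 4 `CCn1c(C(=O)NC2(C(=O)O)CC2)ccc1C(CC)(CC)c1ccc(OCS(=O)(=O)c2ccccc2)c(C)c1`: 1-carboxycyclopropyl in place of 3-hydroxypropyl on an amide-type nitrogen. In words, this is 1-carboxycyclopropyl in place of 3-hydroxypropyl on an amide-type nitrogen. The measured steps at this same nitrogen give some guidance. Placing 2-(methoxycarbonyl)ethyl where 1-(methoxycarbonyl)ethyl stood gave an at least 2.7-fold higher number from compound 1 to compound 2 (0.44 log units; beyond the scatter), while placing hydroxymethyl where methoxycarbonyl stood gave an at least 1.8-fold lower number from compound 2 to compound 3 (0.27 log units; that floor lies within the scatter). For the measured compounds named here, no measured compound carries the 1-carboxycyclopropyl group, so these steps guide only loosely. The nearest group by name is the 1-(methoxycarbonyl)ethyl of compound 1, at 17900 nM, which points to a value close to the one already seen. The expected step is a 1.1-fold higher number from compound 3 to compound 4 (0.02 log units; within the scatter), so no shift beyond the scatter is expected. Compound 4 is estimated at 28000 nM, with an expected range of 11000 nM to 50000 nM.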

Compound 4, half-maximal inhibitory concentration: > 50000 nM
Compound 4: a limit, no number; the forecaster's own chance of this, stated with the estimate: 30%; at least 1.7-fold (0.25 log units) between middle value and limit.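

In this assay compound 4 reads > 50000 nM, which is a limit and not a number. On the amide-type nitrogen, the 1-carboxycyclopropyl group gives an at least 2.7-fold higher number from compound 1 to compound 4 (0.44 log units; beyond the scatter), so a second group at this position now falls clearly behind the 1-(methoxycarbonyl)ethyl of compound 1, while an at least 1.8-fold higher number from compound 3 to compound 4 (0.27 log units; that floor lies within the scatter) does not separate it from the 3-hydroxypropyl of compound 3. Compound 2 and compound 4 cannot be ranked against each other, and the step between them cannot be read, because both stop at the same point: the limit of > 50000 nM in this assay, at which 2 of the 4 values shown sit.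

The 1-carboxycyclopropyl group brings a carboxylic acid and a three-membered ring together, so the compounds shown cannot say which of the two goes with the weaker reading. A 1-carboxyethyl group or a 1-(methoxycarbonyl)cyclopropyl group on this nitrogen would pull the two apart.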